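Changing one end group on an inactive compound

The source may report more compounds than this note shows. Statements on the series, on what has been measured and on what is new or still open speak of the compounds shown alone.

In a functional assay on PC-3 cells (Homo sapiens) for inhibition, read by sulforhodamine B assay, with a stated time of 48 h, tested at 50 uM (on this read-out higher numbers stand for more inhibition of growth at the one concentration tested and lower numbers for less inhibition of growth), compound 1 `COc1cc(/C=C/C(=O)/C=C/c2cccc3ccccc23)ccc1OCc1cn(CCCOc2cc(=O)oc3ccccc23)nn1` gives 8% inhibition, and compound 3 `COc1cc(/C=C/C(=O)/C=C/c2cc(OC)c(OC)c(OC)c2)ccc1OCc1cn(CCOc2cc(=O)oc3ccccc23)nn1` gives 22% inhibition. Compound 2 `COc1ccc(/C=C/C(=O)/C=C/c2ccc(OCc3cn(CCCCCOc4cc(=O)oc5ccccc45)nn3)c(OC)c2)cc1OC` has no single number: it was reported as "not active" (no number reported) with no figure attached, so it can be placed only as a compound without a reported growth inhibition at the one concentration tested.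

Compound 4 `COc1ccccc1/C=C/C(=O)/C=C/c1ccc(OCc2cn(CCCCCOc3cc(=O)oc4ccccc34)nn2)c(OC)c1` has not been measured yet. It differs from compound 2 in one place (2-methoxyphenyl in place of 3,4-dimethoxyphenyl on a double-bonded chain carbon bound to a double-bonded chain carbon), with 2-methoxyphenyl in place of 3,4-dimethoxyphenyl on a double-bonded chain carbon bound to a double-bonded chain carbon.

Going by the values given here, no measured pair shows this change directly, so its size cannot be read from the data. In this assay the expectation is no step beyond the scatter in either direction. This rests on the low readings of the two related compounds, compound 1 at 8% and compound 3 at 22% on the same scale.

Compound 4 is expected at about 10% with an estimated range from 0% to 25% in this measurement.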

Compound 4, percent growth inhibition at one concentration: "not active" (no number reported)
Compound 4 has no reported number here, so the estimate cannot be set against anything.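

In this assay, compound 2 and compound 4 are both reported as not active without a number, so no step can be read between them. Nothing available here bears on this result. Going by these compounds, whether 2-methoxyphenyl in place of 3,4-dimethoxyphenyl changes growth inhibition at all remains open.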